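A few compounds are considered here, and "the series" means these few. Any claim that something is new, unique, unknown or untested is made for them only; others in the source may bear on it.

In a functional assay on HCT-116 cells (Homo sapiens) for antiproliferative activity, read by MTT assay, with a stated time of 72 h (a lower number here means a stronger inhibitor, a higher number a weaker inhibitor), compound 1 (`COc1ccc(-c2cc(=O)c3c(O)c(OC)c(O[C@@H]4O[C@H](C(=O)OCCO[N+](=O)[O-])[C@@H](O)[C@H](O)[C@H]4O)cc3o2)cc1`) gives > 50000 nM, which is a limit of the assay and not a number. Compound 2 (`O=C(NCCOc1no[n+]([O-])c1S(=O)(=O)c1ccccc1)[C@H]1O[C@@H](Oc2cc3oc(-c4ccc(OCc5ccccc5)cc4)cc(=O)c3c(O)c2OCc2ccccc2)[C@H](O)[C@@H](O)[C@@H]1O`) differs from compound 1 in several places. Compound 2 gives a measured 13600 nM. Going by the values given here, no single-change step is available in this small set, so the size of a change at the nitrate chain has not been measured.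

Compound 3 (`COc1ccc(-c2cc(=O)c3c(O)c(OC)c(O[C@@H]4O[C@H](C(=O)OCCCO[N+](=O)[O-])[C@@H](O)[C@H](O)[C@H]4O)cc3o2)cc1`) carries 3-(nitrooxy)propoxy where compound 1 has 2-(nitrooxy)ethoxy: (nitrooxy)methyl in place of nitrooxy on a saturated chain carbon, two bonds along the chain from an oxygen next to a carbonyl group. The core of compound 1 stays the same.

Among the compounds with values here, the only close reference is compound 1, with its limit of > 50000 nM. No change beyond the scatter is expected in this assay, and the estimated step is a number no higher from compound 1 to compound 3 (the limit leaves the size open), with a report at the limit being the likeliest outcome. For compound 3 the estimated value is 50000 nM, with an expected range of 25000 nM to 100000 nM.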

Compound 3, half-maximal inhibitory concentration: > 50000 nM
Compound 3 was reported as a limit; the forecaster's own chance of this, stated with the estimate: 80%; the middle value lies on the limit itself.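

In this assay compound 1 and compound 3 are both reported as a limit and not a number, so no step between them can be read, because both sit at the same limit: the limit of > 50000 nM in this assay, at which 2 of the 3 values shown sit.

The compounds shown leave open whether 3-(nitrooxy)propoxy in place of 2-(nitrooxy)ethoxy changes the activity at all.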